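The source may hold more compounds than are shown below. What is called first, only, known or untested is meant among the compounds shown, and "the series" means these compounds.

In an ADME assay on L6 cells (Rattus norvegicus) for cytotoxicity, read by resazurin assay, with a stated time of 72 h (a lower number here means a stronger inhibitor, a higher number a weaker inhibitor), compound 1 `Cc1occc1C(=O)NC(=O)c1ccccc1O` gives 16 ug/mL and compound 2 `Cc1ccc(C(=O)NC(=O)c2ccccc2O)cc1` gives 46 ug/mL while compound 3 `CC(C)c1ccc(C(=O)NC(=O)c2ccccc2O)cc1` gives 19 ug/mL and so stands within the scatter of compound 1 and beyond the scatter below compound 2. Within the data shown here, compound 4 `O=C(NC(=O)c1ccccc1O)c1ccc(-c2ccccc2)cc1` has phenyl in place of isopropyl on an aromatic carbon as its only difference from compound 3. Among the measured compounds shown here, one measured step bears on this carbon: a 2.4-fold lower number from compound 2 to compound 3 (0.38 log units; beyond the scatter) for isopropyl in place of methyl. A single step makes a thin basis, but another modest move toward a lower number is expected in this assay for this larger group. The expected change is a 1.6-fold lower number from compound 3 to compound 4 (0.20 log units; within the scatter) with wide uncertainty. For compound 4 the estimated value is 12 ug/mL with 5 ug/mL to 28 ug/mL as the expected range.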

Compound 4, half-maximal inhibitory concentration: > 100 ug/mL
Compound 4 was reported as a limit (the forecaster's own chance of this, stated with the estimate: 3%); at least 8.3-fold (0.92 log units) between middle value and limit.
By their numbers in this assay, from the lowest: compounds 1 and 3 (each within the scatter of the next); then compound 2. At a limit, above all of these: compound 4.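

Compound 4 is reported only as a limit in this assay: the limit of > 100 ug/mL in this assay, at which 1 of the 4 values shown sits.

Phenyl in place of isopropyl gives an at least 5.2-fold higher number from compound 3 to compound 4 (0.72 log units; beyond the scatter), and phenyl in place of methyl gives an at least 2.1-fold higher number from compound 2 to compound 4 (0.33 log units; beyond the scatter). This aromatic carbon therefore does not respond in one direction across the three groups: isopropyl gives a lower number than methyl, whereas phenyl gives a higher number than both.

Going by these compounds, it remains open whether a cyclohexyl group, a ring without aromatic carbons, would follow isopropyl or phenyl. On these data alone, what an amine or a carboxylic acid on this carbon would give also remains open.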